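Removing the Trifluoromethyl Group from Compound 1

A few compounds are considered here, and "the series" means these few. Any claim that something is new, unique, unknown or untested is made for them only; others in the source may bear on it.

Compound 1 `COc1cc(-c2nn(-c3cccc(NC(=O)c4cccc(C(F)(F)F)c4)c3)cc2-c2ccncc2)ccc1Cl` is the reference point. In a functional assay on U-251 cells (Homo sapiens) for inhibition, read by sulforhodamine B assay, with a stated time of 48 h (a lower number here means a stronger inhibitor of growth, a higher number a weaker inhibitor of growth), compound 1 reports only a limit, > 50000 nM, and so sits at the limit of > 50000 nM in this assay, at which 1 of the 2 values shown sits. Among the measured compounds shown here, compound 2 `O=C(Nc1cccc(-n2cc(-c3ccncc3)c(-c3ccc(Cl)c(O)c3)n2)c1)Nc1cc(C(F)(F)F)cc(C(F)(F)F)c1` gives 1170 nM in this assay; no single-site step connects it to compound 1. Compound 3 `COc1cc(-c2nn(-c3cccc(NC(=O)c4ccccc4)c3)cc2-c2ccncc2)ccc1Cl` differs from compound 1 by hydrogen in place of trifluoromethyl on an aromatic carbon. For the measured compounds named here, with compound 1 at a limit, no measured pair shows what this change does; the expectation is a step of no size beyond the scatter, most likely another limit. Compound 3 is estimated at 50000 nM, with a range of 15000 nM to 200000 nM. The expected step of a number no higher from compound 1 to compound 3 (the limit leaves the size open) is essentially flat.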

Compound 3, concentration for total growth inhibition: 30800 nM
Estimate against measurement, compound 3: 1.6-fold (0.21 log units) above; low and high end bracket the measured number.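

In this assay, hydrogen in place of trifluoromethyl on this aromatic carbon gives an at least 1.6-fold lower number from compound 1 to compound 3 (0.21 log units; that floor lies within the scatter). Trifluoromethyl at this position is therefore not required for compound 3 to give a measurable number in this assay, although the floor alone establishes no gain. The value of compound 1 is only a limit, so the true size of the step stays open: the limit of > 50000 nM in this assay, at which 1 of the 3 values shown sits.

Open, as far as these compounds go, is how an amine or a carboxylic acid on this carbon would compare with hydrogen in compound 3. Also open, from the compounds shown here alone, is whether the same change would behave alike in a compound with the other substituents of compound 2.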